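The source may hold more compounds than are shown below. What is called first, only, known or untested is meant among the compounds shown, and "the series" means these compounds.

In a functional assay on L1210 cells (Mus musculus) for inhibition (on this read-out lower numbers stand for stronger inhibition and higher numbers for weaker inhibition), three compounds have measured values:

- Compound 1 (`CC(C)CN(CC(=O)N(CC(C)C)NC(=O)OCc1ccccc1)NC(=O)CNNC(=O)CBr`) gives 7600 nM
- Compound 2 (`CC(C)CN(CC(=O)N(CC(C)C)NC(=O)OCc1ccccc1)/N=C/c1cccc(B(O)O)c1`) gives 21200 nM
- Compound 3 (`CC(C)CN(CC(=O)N(Cc1ccccc1)NC(=O)OCc1ccccc1)/N=C/c1cccc(B(O)O)c1`) gives 16900 nM

Compound 2 sits at the upper end of these numbers together with compound 3, and the two are separated only by a 1.3-fold lower number from compound 2 to compound 3 (0.10 log units; within the scatter), which is no more than ordinary scatter. Compound 4 (`CC(C)CN(NC(=O)OCc1ccccc1)C(=O)CN(Cc1cccnc1)/N=C/c1cccc(B(O)O)c1`) departs from compound 2 by a single change (pyridin-3-yl in place of isopropyl on a saturated chain carbon bound to an amine nitrogen), with pyridin-3-yl in place of isopropyl on a saturated chain carbon bound to an amine nitrogen.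

For the measured compounds named here, the nearest precedent is a 1.3-fold lower number from compound 2 to compound 3 (0.10 log units; within the scatter), where phenyl replaced isopropyl on a saturated chain carbon bound to an amide-type nitrogen. That change sits at a different nitrogen, so it is only a guide. Going by the values given here, the one step at the amine nitrogen, a 2.8-fold higher number from compound 1 to compound 2 (0.45 log units; beyond the scatter), was modest and exchanged very different groups. On this evidence, no step beyond the scatter is expected in this assay. For compound 4 the expected value is 16000 nM, with an estimated range of 6000 nM to 40000 nM around it. The estimate corresponds to an expected 1.3-fold lower number from compound 2 to compound 4 (0.12 log units; within the scatter) overall.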

Compound 4, half-maximal inhibitory concentration: 75000 nM
Beside the measured number, compound 4's estimate is 4.7-fold (0.67 log units) below it; the measured number lies above the stated range.
By their numbers in this assay, from the lowest: compound 1; then compounds 3 and 2 (each within the scatter of the next); then compound 4.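

In this assay, the step of a 3.5-fold higher number from compound 2 to compound 4 (0.55 log units; beyond the scatter) is the only one among these compounds that changes just the group on the amine nitrogen, here from isobutyl to (pyridin-3-yl)methyl. It shows that this position is not indifferent to the exchange, and the step lies beyond the scatter, while the step of a 1.3-fold lower number from compound 2 to compound 3 (0.10 log units; within the scatter), made on the amide-type nitrogen, stays within it. Nothing measured on these compounds accounts for the rise in the number.

The compounds shown leave open whether the step follows from the aromatic ring as such or from its ring nitrogen, which a plain benzyl group on the amine nitrogen would help to separate. They also leave open how a longer saturated chain, such as n-hexyl, or a cyclohexylmethyl group would read at this place.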